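The source may hold more compounds than are shown below. What is called first, only, known or untested is meant among the compounds shown, and "the series" means these compounds.

Measured so far in a functional assay on A2780 cells (Homo sapiens) for inhibition, with a stated time of 72 h; on this read-out higher numbers stand for weaker inhibition and lower numbers for stronger inhibition:

Compound 1, `CN1c2ccc(NC(=O)Nc3ccc([N+](=O)[O-])cc3)cc2C(C)(C)C(=O)C1(C)C`: 3800 nM
Compound 2, `CN1c2ccc(NC(=S)Nc3ccc([N+](=O)[O-])cc3)cc2C(C)(C)C(=O)C1(C)C`: 4400 nM
Compound 3, `CN1c2ccc(NC(=O)Nc3ccc(C(F)(F)F)cc3)cc2C(C)(C)C(=O)C1(C)C`: 2580 nM

Compound 1 and compound 3 share a core and differ in one place, (trifluoromethyl in place of nitro on an aromatic carbon). That change gave a 1.5-fold lower number from compound 1 to compound 3 (0.17 log units; within the scatter), so the two values are not distinguished by this assay.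

Compound 2 and compound 1 differ in their cores; the difference between the two cores is not broken down here. Compound 2 and compound 1 lie within the scatter of each other, as do compound 2 and compound 3, so none of the three measured compounds can be set apart from the others on this read-out.

Compound 4, `CN1c2ccc(NC(=S)Nc3ccc(C(F)(F)F)cc3)cc2C(C)(C)C(=O)C1(C)C`, has not been measured in this assay. It stands to compound 2 as compound 3 stands to compound 1: the difference is trifluoromethyl in place of nitro on an aromatic carbon, and the place line reads the same in both cases, so this is the same change made on the core of compound 2 instead of the core of compound 1.

Within the data shown here, the only guide to what the change does is the step from compound 1 to compound 3, which stayed within the scatter. The same kind of outcome is expected here: a step of about a 1.5-fold lower number from compound 2 to compound 4 (0.18 log units; within the scatter) is estimated, resting on compound 1 to compound 3 giving a 1.5-fold lower number from compound 1 to compound 3 (0.17 log units; within the scatter) and on compound 2 starting from 4400 nM. For compound 4 the estimate in this assay is 2900 nM, with a range from 1400 nM to 6500 nM.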

Compound 4, half-maximal inhibitory concentration: 3900 nM
Estimate against measurement, compound 4: 1.3-fold (0.13 log units) below; the range from low to high includes it.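

Made on a second core in this assay, trifluoromethyl in place of nitro gave a 1.1-fold lower number from compound 2 to compound 4 (0.05 log units; within the scatter), so the two values are not distinguished. The step on this core and the earlier step on the other core do not differ from each other: the same change on two cores in this assay, a 1.5-fold lower number (0.17 log units; within the scatter) from compound 1 to compound 3 and a 1.1-fold lower number (0.05 log units; within the scatter) from compound 2 to compound 4, 1.3-fold (0.12 log units) apart, within the scatter of two such steps. This shows that the change carries from one core to the other without a readable difference, but since both steps lie within the scatter, the agreement is only between two small steps, and it does not show that a step of readable size would carry over in the same way, nor does it extend to any core beyond these two.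

The four compounds hold only nitro or trifluoromethyl on the aromatic carbon para to a large group, so they do not tell how much the read-out can respond to the group at this place at all. From the compounds shown here alone, it remains open whether a different group there, such as an amine, a carboxylic acid or a nitrile, would give a step beyond the scatter, and whether such a step would then hold on both cores.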